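Compound 2 to compound 4: hydroxy gives way to propyl

This account rests on a few compounds, and the source may have more. Where it says the series, first, only, none or still open, it means among the compounds named here.

In an ADME assay on MRC5 cells (Homo sapiens) for inhibition, read by MTT assay, with a stated time of 72 h (a higher number here means a weaker inhibitor, a lower number a stronger inhibitor), compound 1 `O=C(OCCCCO)OCCc1ccc(OCc2ccccc2)c(OCc2ccccc2)c1` stands as "not determined" (no result reported) and offers no guide. Compound 2 `O=C(OCCCCCCO)OCCc1ccc(O)c(O)c1` reads > 50000 nM in this assay and this is a limit of the assay, not a number. Compound 3 `O=C(OCCOC(=O)OCCc1ccc(O)c(O)c1)OCCc1ccc(O)c(O)c1` reads > 50000 nM and this too is only a limit. On these data alone, the sole level reached so far is the limit of > 50000 nM in this assay, at which 2 of the 3 values shown sit, and compound 2 is one of those two entries, so its true position remains unknown.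

Compound 4 `CCCCCCCCCOC(=O)OCCc1ccc(O)c(O)c1` has not yet been measured. It carries propyl in place of hydroxy on a saturated chain carbon, six bonds along the chain from an oxygen next to a carbonyl group and is otherwise the same as compound 2.

Going by the values given here, no pair of measured compounds shows a step, so the data give no direct size for this change. The expectation is a modest move toward stronger inhibition in this assay and a result at the same limit remains quite possible. Compound 2 starts from the limit > 50000 nM so any expected numerical result would lie on the stronger side. The estimated change is an at least 2.0-fold lower number from compound 2 to compound 4 (0.30 log units; that floor lies within the scatter) on that reading. For compound 4 the expected value is 25000 nM with an estimated range from 8000 nM to 50000 nM in this measurement.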

Compound 4, half-maximal inhibitory concentration: 15900 nM
Estimate against measurement, compound 4: 1.6-fold (0.20 log units) above, within the range that was stated.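

Among the compounds shown, compound 4 is the only one to give a number in this assay rather than a limit or no result, so this place on the chain now has a measured read-out. Putting propyl in place of hydroxy on a saturated chain carbon, six bonds along the chain from an oxygen next to a carbonyl group, gives an at least 3.1-fold lower number from compound 2 to compound 4 (0.49 log units; beyond the scatter) and so moves the compound to a stronger inhibitor by more than the usual scatter. Only a lower bound on that step can be given, because compound 2 is held by a limit of the assay and not by a number: the limit of > 50000 nM in this assay, at which 2 of the 4 values shown sit.

The change takes away a hydroxy and adds carbon in a single move, so the compounds shown cannot separate the loss of the one from the gain of the other. On these data alone, how a longer chain, or an amine at this same place, would read in this assay stays open, and so does whether the step would keep its size from a parent compound with a true number.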